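This account rests on a few compounds, and the source may have more. Where it says the series, first, only, none or still open, it means among the compounds named here.

In a functional assay on HeLa cells (Homo sapiens) for antiproliferative activity, read by CCK-8 assay, with a stated time of 48 h (on this read-out lower numbers stand for stronger inhibition and higher numbers for weaker inhibition), compound 1 (`COc1ccc(/C=C\c2cc(OC)c(OC)c(OC)c2)cc1OCc1ccc(CNCCO)cc1`) gives 4400 nM and compound 2 (`COc1ccc(/C=C\c2cc(OC)c(OC)c(OC)c2)cc1OCc1ccc(CN2CC[C@H](O)C2)cc1`) gives 10500 nM as the higher of the two numbers. Compound 3 (`COc1ccc(/C=C\c2cc(OC)c(OC)c(OC)c2)cc1OCc1ccc(CNCCN(C)C)cc1`) differs from compound 2 in one place, on a saturated chain carbon bound to an aromatic carbon ((2-(dimethylamino)ethyl)amino in place of 3-hydroxypyrrolidin-1-yl on a saturated chain carbon bound to an aromatic carbon). Within the data shown here, the one measured step bearing on this (a 2.4-fold higher number from compound 1 to compound 2 (0.38 log units; beyond the scatter)) was modest and led into the ring. Compound 3, like compound 1 (4400 nM), has no ring in that group, so a modest step to a lower number is expected in this assay here. For compound 3 the estimated value is 5000 nM in a range from 1800 nM to 12000 nM as expected. The expected change is a 2.1-fold lower number from compound 2 to compound 3 (0.32 log units; beyond the scatter) on these figures.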

Compound 3, half-maximal inhibitory concentration: 9400 nM
Beside the measured number, compound 3's estimate is 1.9-fold (0.27 log units) below it; the measured number falls inside the stated range.
By their numbers in this assay, from the lowest: compound 1; then compounds 3 and 2 (each within the scatter of the next).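

In this assay the ring proves not to be what separates compound 2 from compound 1, since a 1.1-fold lower number from compound 2 to compound 3 (0.05 log units; within the scatter) is the step on replacing 3-hydroxypyrrolidin-1-yl with the open (2-(dimethylamino)ethyl)amino group. With no ring on either side, dimethylamino in place of hydroxy on the chain gives a 2.1-fold higher number from compound 1 to compound 3 (0.33 log units; beyond the scatter), a modest step of about the same size as a 2.4-fold higher number from compound 1 to compound 2 (0.38 log units; beyond the scatter). No evidence is available to explain these results. As far as these compounds go, whether a carboxylic acid or a methoxy group in place of that hydroxy, or a longer chain carrying it, would stay near compound 1 remains open.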